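Diaryl ether series: dichlorophenyl exchanged for methylphenyl

The source may report more compounds than this note shows. Statements on the series, on what has been measured and on what is new or still open speak of the compounds shown alone.

Compound 3 `O=C(O)C[C@@H]1CCCN1c1ccc(Oc2ccc(Cl)cc2Cl)cc1` carries a 2,4-dichlorophenyl on the ether oxygen of the shared core. In a functional assay on cells for agonist activity at Free fatty acid receptor 1 (Homo sapiens), read by FLIPR and calcium flux, with a stated time of 100 s (a higher number here means that more compound is needed for the effect, a lower number that less compound is needed), compound 3 gives 360 nM, which is the higher of the two numbers obtained so far. Compound 1 `O=C(O)C[C@@H]1CCCN1c1ccc(OCc2ccc(Cl)cc2Cl)cn1` is the nearest comparator: in this assay compound 1 gives 220 nM, and the gap to compound 3 lies within the usual scatter, so the two cannot be placed in order. Compound 2 `Cc1ccccc1COc1ccc(N2CCC[C@H]2CC(=O)O)cc1C` gives in this assay only > 33000 nM, a limit of the assay rather than a number, as the limit of > 33000 nM in this assay, at which 1 of the 3 values shown sits, records.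

Compound 4 `Cc1ccc(Oc2ccc(N3CCC[C@H]3CC(=O)O)cc2)cc1` is the next member: 4-methylphenyl in place of 2,4-dichlorophenyl on an oxygen on an aromatic ring. Among the measured compounds shown here, no pair of measured compounds covers this exact change, so the size of the step rests on judgement alone. For the measured compounds named here, both numbers in hand belong to compounds bearing two chlorines on the outer ring, while the sole methyl-bearing member, compound 2, sits at the limit of the assay, so a move toward higher numbers is expected for compound 4. The step is expected to run a 6.9-fold higher number from compound 3 to compound 4 (0.84 log units; beyond the scatter), beyond the scatter. For compound 4 the estimate in this assay is 2500 nM, with a range from 600 nM to 12000 nM.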

Compound 4, half-maximal effective concentration: 490 nM
Beside the measured number, compound 4's estimate is 5.1-fold (0.71 log units) above it; measured number outside the range, below it.
By their numbers in this assay, from the lowest: compounds 1, 3 and 4 (each within the scatter of the next, the first and the last beyond it). At a limit, above all of these: compound 2.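

In this assay, the exchange on an oxygen on an aromatic ring gives a 1.4-fold higher number from compound 3 to compound 4 (0.13 log units; within the scatter), so at this position the 2,4-dichlorophenyl can give way to the 4-methylphenyl with no readable change in the number. Compound 4 also shows that a methyl on the outer ring can go with a measured number, so a methyl there does not by itself go with a limit of the assay. No measured property at hand accounts for this step, and the data shown tie no explanation to it.

Compound 2 remains at a limit of the assay and differs from compound 4 in more than one place, so what separates the two cannot be assigned to any single group: the limit of > 33000 nM in this assay, at which 1 of the 4 values shown sits. Still open, as far as these compounds go, is how a trifluoromethyl, a nitrile or an amine on the outer ring would read in this assay, and whether the exchange would give a similar step on the other cores.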